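The source may report more compounds than this note shows. Statements on the series, on what has been measured and on what is new or still open speak of the compounds shown alone.

In a functional assay on A549 cells (Homo sapiens) for antiproliferative activity, read by sulforhodamine B assay, with a stated time of 48 h (a lower number here means a stronger inhibitor, a higher number a weaker inhibitor), compound 1 (`COc1ccc(-c2ccccc2C(=O)/C=C/c2ccc(F)cc2)cc1OC`) gives 8600 nM and compound 2 (`COc1ccc(/C=C/C(=O)c2ccccc2-c2ccc(OC)c(OC)c2)cc1`) gives 1600 nM as the lower of the two numbers, which makes compound 2 the stronger inhibitor so far. Compound 3 (`COc1ccc(/C=C/C(=O)c2ccccc2-c2ccc(OC)c(OC)c2)cc1OC`) differs from compound 2 in one place, where 4-methoxyphenyl becomes 3,4-dimethoxyphenyl. This puts methoxy in place of hydrogen on an aromatic carbon, ortho to a methoxy group and meta to a large group (methoxy in place of hydrogen on an aromatic carbon). Among the compounds with values here, only one measured step bears on this change, the modest 5.4-fold lower number from compound 1 to compound 2 (0.73 log units; beyond the scatter) when methoxy took the place of fluoro. That step replaced fluoro rather than hydrogen, so it is only a loose guide. A small further fall is expected, possibly no larger than the usual scatter, with an estimated 1.3-fold lower number from compound 2 to compound 3 (0.12 log units; within the scatter) in this measurement. For compound 3 the expected value is 1200 nM within an estimated range of 400 nM to 3800 nM in this assay.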

Compound 3, half-maximal inhibitory concentration: 8500 nM
For compound 3 the middle estimate is 7.1-fold (0.85 log units) below the measured one; the measured number lies above the stated range.
By their numbers in this assay, from the lowest: compound 2; then compounds 3 and 1 (each within the scatter of the next).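

Putting a methoxy group on this aromatic carbon, ortho to a methoxy group, turns 4-methoxyphenyl into 3,4-dimethoxyphenyl and weakens the effect in this assay, with a 5.3-fold higher number from compound 2 to compound 3 (0.73 log units; beyond the scatter). The gain seen when methoxy replaced fluoro therefore does not carry over to a further methoxy group on this ring. Set against the 4-fluorophenyl group, the 3,4-dimethoxyphenyl group gives a result that cannot be told apart, with a 1.0-fold lower number from compound 1 to compound 3 (0.01 log units; within the scatter), and no measurement here explains the effect of the added group.

Still open, from the compounds shown here alone, is whether this loss belongs to methoxy itself or to any group placed on this carbon. A hydroxy group, a chloro group or an amine at the same place would help to settle that question.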